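Side-chain swaps: from compound 3 to compound 4

A few compounds are considered here, and "the series" means these few. Any claim that something is new, unique, unknown or untested is made for them only; others in the source may bear on it.

Measured in an ADME assay on microsomes from liver (Homo sapiens) for metabolic stability, read by LC-MS, tested at 1 uM; a lower number here means slower removal, a higher number faster removal of the compound
- compound 1 `c1cc([C@H]2CC[C@]3(CC2)OOC2(O3)C3CC4CC(C3)CC2C4)ccc1OCCCNC1CCOCC1` gives 10 mL.min-1.g-1
- compound 2 `NCCCOc1ccc([C@H]2CC[C@]3(CC2)OOC2(O3)C3CC4CC(C3)CC2C4)cc1` gives < 7 mL.min-1.g-1
- compound 3 `NC(=O)C1CCN(Cc2ccc([C@H]3CC[C@]4(CC3)OOC3(O4)C4CC5CC(C4)CC3C5)cc2)CC1` gives 10 mL.min-1.g-1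

The entry for compound 2 is a limit of the assay, not a number.

In this assay compound 3 gives 10 mL.min-1.g-1 and so stands level with compound 1. The next change leads to compound 4 `c1cc([C@H]2CC[C@]3(CC2)OOC2(O3)C3CC4CC(C3)CC2C4)ccc1OCCOC1CCNCC1` and is counted as 2-((piperidin-4-yl)oxy)ethoxy in place of (4-carbamoylpiperidin-1-yl)methyl on an aromatic carbon in the structure. In words, it puts 2-((piperidin-4-yl)oxy)ethoxy in place of (4-carbamoylpiperidin-1-yl)methyl on an aromatic carbon, para to a large group. Two measured swaps at that aromatic carbon bear on it (no change at the digits printed from compound 1 to compound 3 (within the scatter)) and (an at least 1.4-fold higher number from compound 2 to compound 3 (0.15 log units; that floor lies within the scatter)). The change on the amine nitrogen adds a third step (an at least 1.4-fold lower number from compound 1 to compound 2 (0.15 log units; that floor lies within the scatter)). None of these steps goes beyond the scatter, so no step beyond the scatter is expected here, in either direction. The expected step is small (no change at the digits printed from compound 3 to compound 4 (within the scatter)). The estimate for compound 4 is 10 mL.min-1.g-1 with 7 mL.min-1.g-1 to 20 mL.min-1.g-1 as its expected range.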

Compound 4, intrinsic clearance in microsomes: < 7 mL.min-1.g-1
Compound 4 gave a limit, no number; the forecaster's own chance of this, stated with the estimate: 25%; middle value at least 1.4-fold (0.15 log units) from the limit.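

In this assay compound 4 gives < 7 mL.min-1.g-1, which is a limit of the assay and not a number. From the compounds shown here alone, the steps of an at least 1.4-fold lower number from compound 3 to compound 4 (0.15 log units; that floor lies within the scatter) and an at least 1.4-fold lower number from compound 1 to compound 4 (0.15 log units; that floor lies within the scatter) are therefore floors only, and the true size of the change at this aromatic carbon, para to a large group, remains unknown. Reaching the limit is thus not confined to the 3-aminopropoxy side chain of compound 2, as 2-((piperidin-4-yl)oxy)ethoxy in compound 4 reaches it as well: the limit of < 7 mL.min-1.g-1 in this assay, at which 2 of the 4 values shown sit.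

The step between compound 2 and compound 4 cannot be read, as both entries are limits, so these two side chains cannot be ordered. Also open, going by these compounds, is how a carboxylic acid or a longer chain ending in an amine would read at this aromatic carbon.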